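The source may hold more compounds than are shown below. What is called first, only, known or untested is meant among the compounds shown, and "the series" means these compounds.

Measured compounds in a functional assay for inhibition of sodium/hydrogen exchanger (Oryctolagus cuniculus); a higher number here means a weaker inhibitor, a lower number a stronger inhibitor:
compound 1, `Cc1cc(C2CCC2)c(S(C)(=O)=O)cc1C(=O)N=C(N)N`, 8.2 nM;
compound 2, `Cc1cc(Nc2ncccn2)c(S(C)(=O)=O)cc1C(=O)N=C(N)N`, 8.3 nM.

Compound 2 gives the highest of the two numbers in this assay, with compound 1 close by: a 1.0-fold higher number from compound 1 to compound 2 (0.01 log units; within the scatter). Compound 3, `Cc1ccc(S(C)(=O)=O)cc1C(=O)N=C(N)N`, is not yet measured. It differs from compound 2 by hydrogen in place of (pyrimidin-2-yl)amino on an aromatic carbon. Among the measured compounds shown here, no measured step covers loss of a group at this position; the only step at hand swaps one group for another there and stays within the scatter. The step to compound 3 in this assay is therefore uncertain, and a weaker number is expected: a 3.6-fold higher number from compound 2 to compound 3 (0.56 log units; beyond the scatter). Compound 3 is estimated at 30 nM, within 8 nM to 120 nM.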

Compound 3, half-maximal inhibitory concentration: 150 nM
Compound 3: middle estimate off by 5.0-fold (0.70 log units), on the low side, and the stated range ends below it.
By their numbers in this assay, from the lowest: compounds 1 and 2 (each within the scatter of the next); then compound 3.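

Replacing either group with hydrogen on this aromatic carbon, ortho to the methylsulfonyl group, gives in this assay an 18-fold higher number from compound 2 to compound 3 (1.26 log units; beyond the scatter) and an 18-fold higher number from compound 1 to compound 3 (1.26 log units; beyond the scatter). The earlier swap between cyclobutyl and (pyrimidin-2-yl)amino showed no change beyond the scatter; these steps show that, for these compounds, a substituent at this position matters, and that two quite different groups serve alike. No available evidence bears on the reason for this.

From the compounds shown here alone, whether a single chlorine atom or a small amine here would already give the lower numbers remains open. So does whether a carboxylic acid would be tolerated at this position.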